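Removing one aromatic chloro from an inactive dienaminone pair

This account rests on a few compounds, and the source may have more. Where it says the series, first, only, none or still open, it means among the compounds named here.

Compound 1 `CC1(C)CC(=O)C=C(Nc2ccc(Cl)cc2Cl)C1` is tested in a functional assay on cells (blood, Homo sapiens) for inhibition, read by chemiluminescence, with a stated time of 30 min (on this read-out higher numbers stand for weaker inhibition and lower numbers for stronger inhibition), and is known there only by a limit: compound 1 gives > 100 ug/mL, which is a limit of the assay and not a number. Among the measured compounds shown here, compound 2 `CCCCSC(=S)C1=C(Nc2ccc(Cl)cc2Cl)CC(C)(C)CC1=O` is the only neighbour measured; in this assay compound 2 gives > 100 ug/mL, again a limit rather than a number. The step from compound 1 to compound 2 is therefore a step that the two limits leave unreadable from compound 1 to compound 2, since (the limit of > 100 ug/mL in this assay, at which 2 of the 2 values shown sit); nothing about its size can be read.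

Compound 3 `CC1(C)CC(=O)C=C(Nc2ccc(Cl)cc2)C1` differs from compound 1 as follows: hydrogen in place of chloro on an aromatic carbon. The chloro that leaves sits on an aromatic carbon of a six-membered aromatic ring of carbon only, ortho to a large group and meta to a chloro group. For the measured compounds named here, no measured step touches that position, and the one measured step is unreadable, so no direction can be drawn from the numbers. Given that compound 1 sits at > 100 ug/mL, the most likely outcome is that compound 3 also returns only a limit. The estimate for compound 3 in this assay is 150 ug/mL, with an expected range of 50 ug/mL to 400 ug/mL. The step this estimate implies is expected to be a step that the limit leaves unreadable from compound 1 to compound 3, with no expectation of a change beyond the scatter.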

Compound 3, half-maximal inhibitory concentration: > 100 ug/mL
Compound 3: a limit, no number; the forecaster's own chance of this, stated with the estimate: 85%; the middle value is on the limit's open side.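

In this assay compound 3 gives > 100 ug/mL, a limit of the assay and not a number. No step between compound 1 and compound 3 can be read: the limit of > 100 ug/mL in this assay, at which 3 of the 3 values shown sit.

Going by these compounds, what the chloro on the aromatic carbon contributes to inhibition, and which change to the shared core would give a readable value, stays open across compound 1, compound 2 and compound 3.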